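The source may hold more compounds than are shown below. What is called first, only, known or untested is meant among the compounds shown, and "the series" means these compounds.

Three amides on the shared core have been measured in an ADME assay on HepG2 cells (Homo sapiens) for cytotoxicity, with a stated time of 3 days; on this read-out higher numbers stand for lower toxicity in this test and lower numbers for higher toxicity in this test. Compound 1 `CC(CSc1nnc(-c2ccncc2)s1)C(=O)NCc1ccccc1Cl` stands at a limit of the test: in this assay compound 1 gives > 50000 nM. Compound 2 `CC(CSc1nnc(-c2ccncc2)s1)C(=O)Nc1ccc(Cl)cc1` likewise stands at a limit: in this assay compound 2 gives > 50000 nM. Compound 3 `CC(CSc1nnc(-c2ccncc2)s1)C(=O)NCc1ccccc1` also stands at a limit: in this assay compound 3 gives > 50000 nM. All three values sit at the limit of > 50000 nM in this assay, at which 3 of the 3 values shown sit, so the steps among them cannot be sized: a step that the two limits leave unreadable from compound 1 to compound 2, a step that the two limits leave unreadable from compound 1 to compound 3 and a step that the two limits leave unreadable from compound 2 to compound 3 are all unreadable. Compound 3 thus stands where every measured compound stands, with no spread to rank it.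

Compound 4 `CC(CSc1nnc(-c2ccncc2)s1)C(=O)Nc1ccccc1Cl` differs from compound 3 in one place: 2-chlorophenyl in place of benzyl on an amide-type nitrogen. The measured steps that bear on this change, the exchange of benzyl for an aryl amide and the removal of a chloro, are a step that the two limits leave unreadable from compound 2 to compound 3 and a step that the two limits leave unreadable from compound 1 to compound 3; both are unreadable because every value sits at the limit of > 50000 nM in this assay, at which 3 of the 3 values shown sit. No readable step exists in either direction. The step that the limit leaves unreadable from compound 3 to compound 4 is therefore expected to be none beyond the scatter. For compound 4 the estimate is 80000 nM with a range of 30000 nM to 300000 nM, most likely reported again as a limit.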

Compound 4, half-maximal cytotoxic concentration: > 50000 nM
Compound 4 was reported as a limit; the forecaster's own chance of this, stated with the estimate: 85%; the middle value is on the limit's open side.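

No new step can be read: compound 4 sits at the same limit as compound 1, compound 2 and compound 3, so all its steps stay unreadable: the limit of > 50000 nM in this assay, at which 4 of the 4 values shown sit.

The compounds shown leave open whether any change on the amide-type nitrogen separates these amides in this test.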